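A few compounds are considered here, and "the series" means these few. Any claim that something is new, unique, unknown or untested is made for them only; others in the source may bear on it.

Compound 1 `O=C(c1ccccc1F)N1CCN(c2nc(=O)c3cc(C(F)(F)F)cc([N+](=O)[O-])c3s2)CC1`: > 125000 nM
Compound 2 `CC(C)(C)C(=O)N1CCN(c2nc(=O)c3cc(C(F)(F)F)cc([N+](=O)[O-])c3s2)CC1`: > 125000 nM
Compound 3 `O=C(C1CCCCC1)N1CCN(c2nc(=O)c3cc(C(F)(F)F)cc([N+](=O)[O-])c3s2)CC1`: 88700 nM

In an ADME assay on Vero cells (Chlorocebus sabaeus) for cytotoxicity, read by MTT assay, with a stated time of 72 h (on this read-out higher numbers stand for lower toxicity in this test and lower numbers for higher toxicity in this test), the value given for compound 1 is a limit of the assay and not a number. The value given for compound 2 is that same limit (the limit of > 125000 nM in this assay, at which 2 of the 3 values shown sit). Among the measured compounds shown here, compound 3 therefore stands as the only number among the three values shown. Compound 4 `CCCC(=O)N1CCN(c2nc(=O)c3cc(C(F)(F)F)cc([N+](=O)[O-])c3s2)CC1` differs from compound 3 by propyl in place of cyclohexyl on a carbonyl carbon. For the measured compounds named here, two measured steps bear on this change, an at least 1.4-fold lower number from compound 1 to compound 3 (0.14 log units; that floor lies within the scatter) and an at least 1.4-fold lower number from compound 2 to compound 3 (0.14 log units; that floor lies within the scatter), each only a floor that lies inside the scatter. Because an at least 1.4-fold lower number from compound 1 to compound 3 (0.14 log units; that floor lies within the scatter) and an at least 1.4-fold lower number from compound 2 to compound 3 (0.14 log units; that floor lies within the scatter) both stay within the scatter, compound 4 is expected to show a 1.1-fold higher number from compound 3 to compound 4 (0.05 log units; within the scatter) in this assay, with no step beyond the scatter. Compound 4 is estimated at 100000 nM, within a range from 40000 nM to 250000 nM.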

Compound 4, half-maximal cytotoxic concentration: > 125000 nM
Compound 4 gave a limit, no number (the forecaster's own chance of this, stated with the estimate: 40%); middle value at least 1.2-fold (0.09 log units) away from the limit.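

In this assay compound 4 carries a limit of the assay and not a number, the third such value in the set: the limit of > 125000 nM in this assay, at which 3 of the 4 values shown sit. Propyl in place of cyclohexyl on this carbonyl carbon gives an at least 1.4-fold higher number from compound 3 to compound 4 (0.14 log units; that floor lies within the scatter), so no change beyond the scatter can be claimed for this swap. The steps to compound 4 from compound 1 and from compound 2 cannot be read.

From the compounds shown here alone, whether an amine, a carboxylic acid or a chain longer than propyl on this carbonyl carbon would give a lower number remains open. So does the true size of the values behind the limits.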